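A few compounds are considered here, and "the series" means these few. Any claim that something is new, unique, unknown or untested is made for them only; others in the source may bear on it.

Compound 1 `C[C@@H]1Cc2cc(C(N)=O)cnc2N1` is the reference point of this small set. In an ADME assay on microsomes from liver (Mus musculus) for metabolic stability, read by LC-MS, with a stated time of 60 min (on this read-out lower numbers stand for a less stable compound and higher numbers for a more stable compound), compound 1 gives 93%. Compound 2 `NC(=O)c1cnc2c(c1)CCN2` differs from it by hydrogen in place of methyl on a saturated ring carbon, and in this assay compound 2 gives 89%; the step of a number 4 percentage points lower from compound 1 to compound 2 (within the scatter) shows that removing the methyl from the saturated ring carbon leaves the read-out essentially where it was.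

Compound 3 `Cc1c(C(N)=O)cnc2c1C[C@@H](C)N2` carries a second change relative to compound 1, namely (methyl in place of hydrogen on an aromatic carbon). For compound 3 the outcome in this assay is reported only as "unstable" (no number reported), with no number attached, so a numerical comparison with compound 1 is not possible.

Compound 4 `Cc1c(C(N)=O)cnc2c1CCN2` is not yet measured. It differs from compound 3 by hydrogen in place of methyl on a saturated ring carbon, the same change as from compound 1 to compound 2. Because that step, a number 4 percentage points lower from compound 1 to compound 2 (within the scatter), was within the scatter, compound 4 is expected to stay close to where compound 3 stands. Compound 4 is therefore estimated to give 15% in this assay, with a range from 2% to 45%.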

Compound 4, percent of the compound remaining: 47%
Compound 4: middle estimate off by 32 percentage points, on the low side; measured number outside the range, above it.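

In this assay the swap of methyl for hydrogen on an aromatic carbon comes with a large drop on the core of compound 2 (a number 42 percentage points lower from compound 2 to compound 4 (beyond the scatter)), a step beyond the scatter. The same change on the core of compound 1 leads to compound 3, but that step and the step from compound 3 to compound 4 cannot be read: compound 3 carries only the word "unstable", which points the same way but gives no size, so the result shows a loss of stability on one core and does not show that the change costs the same amount on the other. Nothing measured here bears on why the methyl has this effect.

The compounds shown leave open whether an ethyl group, a chlorine atom or a nitrile in place of that aromatic methyl would go the same way. They also leave open whether any group on that aromatic carbon keeps the stability of compound 2.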